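Methoxy on the cinnamamide: a step without precedent

This account rests on a few compounds, and the source may have more. Where it says the series, first, only, none or still open, it means among the compounds named here.

Compound 1 `CN1[C@@H]2c3[nH]c4ccccc4c3C[C@H]1[C@H](C#N)N1[C@@H](CNC(=O)c3cccc4c3CCCC4)c3[nH]c4ccccc4c3C[C@@H]21`: in a functional assay on HCT-116 cells (Homo sapiens) for cytotoxicity, read by MTT assay, with a stated time of 72 h (on this read-out lower numbers stand for stronger inhibition and higher numbers for weaker inhibition), compound 1 gives 4210 nM.
Compound 2 `CN1[C@@H]2c3[nH]c4ccccc4c3C[C@H]1[C@H](C#N)N1[C@@H](CNC(=O)c3cc4ccccc4o3)c3[nH]c4ccccc4c3C[C@@H]21`: in this assay compound 2 gives 330 nM.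
Compound 3 `CN1[C@@H]2c3[nH]c4ccccc4c3C[C@H]1[C@H](C#N)N1[C@@H](CNC(=O)/C=C/c3ccccc3)c3[nH]c4ccccc4c3C[C@@H]21`: in this assay compound 3 gives 1960 nM.

Compound 3 holds the second highest number of the three. Against compound 1 it shows a 2.1-fold lower number from compound 1 to compound 3 (0.33 log units; beyond the scatter), and against compound 2 it shows a 5.9-fold higher number from compound 2 to compound 3 (0.77 log units; beyond the scatter), so compound 3 sits between the two, closer to compound 1 than to compound 2.

Compound 4 `COc1ccc(/C=C/C(=O)NC[C@H]2c3[nH]c4ccccc4c3C[C@H]3[C@H]4c5[nH]c6ccccc6c5C[C@@H]([C@H](C#N)N23)N4C)cc1` differs from compound 3 by methoxy in place of hydrogen on an aromatic carbon. Every measured step here exchanges the whole group on the carbonyl carbon: a 13-fold lower number from compound 1 to compound 2 (1.11 log units; beyond the scatter) was large, and the other two steps were modest. Among the measured compounds shown here, none of them adds or removes a substituent on an aromatic ring while keeping the rest of the group, so no measured step bears directly on this change. In the absence of such a precedent, the step from compound 3 to compound 4 is expected to stay within the usual scatter, with no clear direction, as a 1.2-fold lower number from compound 3 to compound 4 (0.06 log units; within the scatter). Compound 4 is therefore estimated at 1700 nM in this assay, with a range from 600 nM to 5000 nM.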

Compound 4, half-maximal inhibitory concentration: 5060 nM
The estimate for compound 4 lay 3.0-fold (0.47 log units) below the measured number; the whole stated range lies below it.
By their numbers in this assay, from the lowest: compound 2; then compound 3; then compounds 1 and 4 (each within the scatter of the next).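

In this assay, the first change made on the aromatic ring rather than to the whole group on the carbonyl carbon has a measurable effect: methoxy, para to a large group, gives a 2.6-fold higher number from compound 3 to compound 4 (0.41 log units; beyond the scatter), so this ring carbon does not tolerate the change without a cost in inhibition. The modest advantage of 2-phenylethenyl over 1,2,3,4-tetrahydronaphthalen-5-yl does not survive the addition, as the comparison with the fused ring group is now a 1.2-fold higher number from compound 1 to compound 4 (0.08 log units; within the scatter), while the large gap to 1-benzofuran-2-yl grows to a 15-fold higher number from compound 2 to compound 4 (1.19 log units; beyond the scatter). No measurement available here accounts for this rise in the number.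

The compounds shown leave open whether the rise belongs to methoxy itself or would also follow with a hydroxyl, a methyl or a chlorine on the same aromatic carbon. They also leave open whether methoxy would give the same result on another carbon of this ring, or on the ring of the 1-benzofuran-2-yl group of compound 2, which has the lowest number of the four.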